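This account rests on a few compounds, and the source may have more. Where it says the series, first, only, none or still open, it means among the compounds named here.

Measured so far in an ADME assay on THP-1 cells (Homo sapiens) for cytotoxicity; a higher number here means a weaker inhibitor, a lower number a stronger inhibitor:
compound 1 `COc1ccccc1-c1nnc(-c2ccc(C(=O)N/N=C/c3ccc(F)cc3)cc2)o1` gives 427000 nM
compound 2 `COc1ccccc1-c1nnc(-c2ccc(C(=O)N/N=C/c3cccc(O)c3O)cc2)o1` gives 102000 nM
compound 3 `COc1ccccc1-c1nnc(-c2ccc(C(=O)N/N=C/c3cccc(F)c3)cc2)o1` gives 353000 nM

Compound 1 has the highest number of the three; compound 3 lies within the scatter of it, compound 2 clearly lower. Compound 4 `COc1ccccc1-c1nnc(-c2ccc(C(=O)N/N=C/c3ccccc3O)cc2)o1` differs from compound 1 by 2-hydroxyphenyl in place of 4-fluorophenyl on a carbon with a double bond to nitrogen. Two measured steps start from compound 1 and bear on this change: a 4.2-fold lower number from compound 1 to compound 2 (0.62 log units; beyond the scatter), whereas a 1.2-fold lower number from compound 1 to compound 3 (0.08 log units; within the scatter). Exchanging the fluorophenyl on the carbon with a double bond to nitrogen for a hydroxylated phenyl went with the lower number, and compound 4 carries a hydroxyphenyl rather than the dihydroxyphenyl of compound 2. A modest step to a lower number in this assay is therefore expected, a 2.1-fold lower number from compound 1 to compound 4 (0.33 log units; beyond the scatter). Compound 4 is estimated at 200000 nM, within 80000 nM to 450000 nM.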

Compound 4, half-maximal inhibitory concentration: 207000 nM
Estimate against measurement, compound 4: 1.0-fold (0.01 log units) below; low and high end bracket the measured number.
By their numbers in this assay, from the lowest: compound 2; then compounds 4, 3 and 1 (each within the scatter of the next, the first and the last beyond it).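

In this assay, a single hydroxy on the phenyl is enough for a step beyond the scatter: a 2.1-fold lower number from compound 1 to compound 4 (0.31 log units; beyond the scatter) with 2-hydroxyphenyl in place of 4-fluorophenyl. Against 3-fluorophenyl the same group gives a 1.7-fold lower number from compound 3 to compound 4 (0.23 log units; within the scatter) and stays within the scatter. Hydrogen in place of hydroxy on an aromatic carbon gives a 2.0-fold higher number from compound 2 to compound 4 (0.31 log units; beyond the scatter) and so separates compound 2, with its second hydroxy, from the single hydroxy of compound 4.

Going by these compounds, whether an amine or a carboxylic acid on this phenyl would follow the hydroxy compounds stays open. Nothing at hand bears on the reason for these steps.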